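Lengthening the Linker to a Second Basic Ring

This account rests on a few compounds, and the source may have more. Where it says the series, first, only, none or still open, it means among the compounds named here.

Two compounds have been measured in an assay on HEK293 cells for displacement of a labelled ligand from 5-hydroxytryptamine receptor 4 (Homo sapiens), read by scintillation counting; a lower number here means a stronger inhibitor, a higher number a weaker inhibitor:
Compound 1 `CCN1CCC(NC(=O)c2cc(Cl)c(N)cc2OC)CC1` gives 1000 nM.
Compound 2 `COc1cc(N)c(Cl)cc1C(=O)NC1CCN(CCN2CCCCC2)CC1` gives 251 nM.

Among the measured compounds shown here, compound 2 stands at the lower of the two numbers; its only neighbour is compound 1, and the step of a 4.0-fold lower number from compound 1 to compound 2 (0.60 log units; beyond the scatter) is the sole measured change in this set. Compound 3 `COc1cc(N)c(Cl)cc1C(=O)NC1CCN(CCCCCN2CCCCC2)CC1` has not yet been measured. It differs from compound 2 by 3-(piperidin-1-yl)propyl in place of piperidin-1-yl on a saturated chain carbon, two bonds along the chain from an amine nitrogen in a ring. For the measured compounds named here, the one step that bears on this change, a 4.0-fold lower number from compound 1 to compound 2 (0.60 log units; beyond the scatter), shows that attaching the second ring through a short chain lowered the number. Whether a longer chain to the same ring helps further is not shown by any measured pair here, so the step of a 1.3-fold lower number from compound 2 to compound 3 (0.10 log units; within the scatter) is expected to stay within the scatter, with no direction strongly favoured. Compound 3 is therefore estimated at 200 nM in this assay, within a range of 50 nM to 800 nM.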

Compound 3, inhibition constant: 10 nM
Estimate against measurement, compound 3: 20-fold (1.30 log units) above; measured number outside the range, below it.
By their numbers in this assay, from the lowest: compound 3; then compound 2; then compound 1.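

In this assay, among the compounds shown here, the length of the chain leading to the piperidin-1-yl ring matters more at this position than the earlier compounds suggested: the step to the 3-(piperidin-1-yl)propyl group (a 25-fold lower number from compound 2 to compound 3 (1.40 log units; beyond the scatter)) is larger than the step that first brought the ring in (a 4.0-fold lower number from compound 1 to compound 2 (0.60 log units; beyond the scatter)). The entering and leaving groups carry the same ring and the same counts of hydrogen-bond donors and acceptors, so they differ in the added chain, and the whole change from the simple ethyl compound is large (a 100-fold lower number from compound 1 to compound 3 (2.00 log units; beyond the scatter)). Nothing available here explains why this chain gives the lower number.

As far as these compounds go, whether a still longer chain would lower the number further remains open. So does whether the piperidin-1-yl ring at the chain end could give way to a dimethylamino group while keeping the low number of compound 3.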